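Furan-3-yl Replaces the Pyrrolidinylpyridyl Group on the Core

This account rests on a few compounds, and the source may have more. Where it says the series, first, only, none or still open, it means among the compounds named here.

Compound 3 `O=C(O)Cc1sc(C(c2ccc(F)cc2)c2ccc(F)cc2)nc1-c1ccnc(N2CCCC2)c1` stands second highest of the three numbers in an in vitro assay on HEK385-7 cells for displacement of a labelled ligand from prostaglandin D2 receptor 2 (Homo sapiens) (on this read-out higher numbers stand for weaker inhibition and lower numbers for stronger inhibition), where compound 3 gives 230 nM. Its nearest neighbour is compound 1 `O=C(O)Cc1sc(C(c2ccc(F)cc2)c2ccc(F)cc2)nc1-c1ccnc(N2CCC2)c1`, which in this assay gives 660 nM; the step of a 2.9-fold lower number from compound 1 to compound 3 (0.46 log units; beyond the scatter) separates them. Furthest away is compound 2 `O=C(O)Cc1sc(C(c2ccc(F)cc2)c2ccc(F)cc2)nc1-c1ccccc1`, which in this assay gives 16 nM; here the step is a 14-fold higher number from compound 2 to compound 3 (1.16 log units; beyond the scatter), and against compound 1 it is a 41-fold lower number from compound 1 to compound 2 (1.62 log units; beyond the scatter).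

Compound 4 `O=C(O)Cc1sc(C(c2ccc(F)cc2)c2ccc(F)cc2)nc1-c1ccoc1` differs from compound 3 in one place: furan-3-yl in place of 2-(pyrrolidin-1-yl)pyridin-4-yl on an aromatic carbon.

Among the compounds with values here, two measured steps bear on this change. The step of a 14-fold higher number from compound 2 to compound 3 (1.16 log units; beyond the scatter) shows that putting a 2-(pyrrolidin-1-yl)pyridin-4-yl where a phenyl stood raised the number by a large amount, whereas a 2.9-fold lower number from compound 1 to compound 3 (0.46 log units; beyond the scatter) shows only a modest shift between the two pyridyl groups that each carry an attached ring. Furan-3-yl, like phenyl, carries no such attached ring, so a large step downward in this assay is expected, though whether a five-membered aromatic ring with one hetero atom behaves like phenyl is untested among these compounds. The estimate for compound 4 is therefore a step of a 7.7-fold lower number from compound 3 to compound 4 (0.88 log units; beyond the scatter), giving an expected 30 nM with a range from 8 nM to 120 nM.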

Compound 4, half-maximal inhibitory concentration: 14 nM
Beside the measured number, compound 4's estimate is 2.1-fold (0.33 log units) above it, and the stated range covers the measured number.
By their numbers in this assay, from the lowest: compounds 4 and 2 (each within the scatter of the next); then compound 3; then compound 1.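

In this assay, the furan-3-yl of compound 4 and the phenyl of compound 2 cannot be told apart, with a 1.1-fold lower number from compound 2 to compound 4 (0.06 log units; within the scatter). Within the data shown here, this shows that on this aromatic carbon, next to the ring nitrogen, a five-membered aromatic ring with 1 hetero atom can stand in for phenyl, which the earlier compounds left untested. The two pyridyl groups that each carry an attached ring stay well apart from furan-3-yl, with a 16-fold lower number from compound 3 to compound 4 (1.22 log units; beyond the scatter) and a 47-fold lower number from compound 1 to compound 4 (1.67 log units; beyond the scatter), so the high numbers of the earlier compounds now stand against two different groups without such a ring, though nothing at hand accounts for this gap.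

What the compounds shown leave open is which part of the pyridyl groups goes with the higher numbers, since a bare pyridin-4-yl or a phenyl bearing a pyrrolidin-1-yl group is not among them to separate the ring nitrogen from the attached ring. They also leave open how far the tolerance for furan-3-yl extends, for instance to furan-2-yl, thiophen-3-yl, or a furan-3-yl carrying a methyl group.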